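The compounds below may be only part of what the source reports. "The series", "measured", "known", "first", "only" and "open" are said of these compounds alone.

Series notes, compound 2 to compound 4. Within the data shown here, compound 2 `Fc1ccc2nc(-c3cncs3)n(C3CC3)c2c1` gives 62 nM in an assay on cells for inhibition of cytochrome P450 11B2, mitochondrial (Homo sapiens), read by HPLC, with a stated time of 90 min (a lower number here means a stronger inhibitor, a higher number a weaker inhibitor), and holds the lowest number of the three measured members; compound 3 `Fc1ccc2nc(-c3cccnn3)n(C3CC3)c2c1` gives 412 nM, the step being a 6.6-fold higher number from compound 2 to compound 3 (0.82 log units; beyond the scatter), and compound 1 `Fc1ccc2nc(-n3ccnn3)n(C3CC3)c2c1` gives 1060 nM, with a 17-fold lower number from compound 1 to compound 2 (1.23 log units; beyond the scatter). Compound 4 `Fc1ccc2nc(-c3ccnnc3)n(C3CC3)c2c1` differs from compound 2 by pyridazin-4-yl in place of 1,3-thiazol-5-yl on an aromatic carbon. Among the measured compounds shown here, the only measured step that bears on this change is the one from compound 2 to compound 3, where another pyridazinyl replaced the same 1,3-thiazol-5-yl and the number rose modestly. A step of similar size and direction is therefore expected here, a 5.6-fold higher number from compound 2 to compound 4 (0.75 log units; beyond the scatter), though which pyridazinyl isomer matters is not shown. Compound 4 is estimated at 350 nM, within 110 nM to 1100 nM.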

Compound 4, half-maximal inhibitory concentration: 330 nM
Compound 4: middle estimate off by 1.1-fold (0.03 log units), on the high side; measured number inside the range.
By their numbers in this assay, from the lowest: compound 2; then compounds 4 and 3 (each within the scatter of the next); then compound 1.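

In this assay the placing of the ring nitrogens within the pyridazinyl group makes no readable difference, with a 1.2-fold lower number from compound 3 to compound 4 (0.10 log units; within the scatter) inside the scatter. The loss against 1,3-thiazol-5-yl therefore holds for both pyridazinyl isomers, with a 5.3-fold higher number from compound 2 to compound 4 (0.73 log units; beyond the scatter) for this one, and pyridazin-4-yl still keeps an edge over 1H-1,2,3-triazol-1-yl, with a 3.2-fold lower number from compound 1 to compound 4 (0.51 log units; beyond the scatter) at this position. Nothing available explains the order of these rings.

Going by these compounds, whether a pyridine or a thiophene at this position would match compound 2 remains open. So does the effect of an amine or a methyl group on the pyridazinyl ring.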